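From methoxy to nitro on compound 3

A few compounds are considered here, and "the series" means these few. Any claim that something is new, unique, unknown or untested is made for them only; others in the source may bear on it.

compound 1 `N#C/C(=C\c1ccccc1OS(=O)(=O)c1ccc([N+](=O)[O-])cc1)C(=O)Nc1nnc(-c2cccs2)s1`: 33%
compound 2 `N#C/C(=C\c1ccccc1OS(=O)(=O)c1ccc([N+](=O)[O-])cc1)C(=O)Nc1nnc(Cc2cccc3ccccc23)s1`: 25%
compound 3 `COc1ccc(S(=O)(=O)Oc2ccccc2/C=C(\C#N)C(=O)Nc2nnc(Cc3cccc(F)c3)s2)cc1`: 29%

All three values come from an ADME assay on HEK-293T cells (Homo sapiens) for inhibition, read by CCK-8 assay, with a stated time of 48 h, tested at 20 uM; on this read-out higher numbers stand for more inhibition of growth at the one concentration tested and lower numbers for less inhibition of growth. Compound 3, at 29%, lies within the scatter of both compound 1 and compound 2. Compound 4 `N#C/C(=C\c1ccccc1OS(=O)(=O)c1ccc([N+](=O)[O-])cc1)C(=O)Nc1nnc(Cc2cccc(F)c2)s1` differs from compound 3 in one place: nitro in place of methoxy on an aromatic carbon. This puts nitro in place of methoxy on an aromatic carbon, para to a large group. Within the data shown here, the only measured step, a number 8 percentage points lower from compound 1 to compound 2 (within the scatter), lies elsewhere in the structure and does not cover this change. Compound 1 and compound 2 already carry the (4-nitrophenyl)sulfonyl group, and neither value stands beyond the scatter from compound 3, so no shift beyond the scatter is expected in this assay. The expected step is no change at the digits printed from compound 3 to compound 4 (within the scatter). For compound 4 the estimated value is 29%, with an expected range of 18% to 40%.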

Compound 4, percent growth inhibition at one concentration: "not toxic" (no number reported)
For compound 4 the study gives words and no number; the estimate stays without a comparison.
By their numbers in this assay, from the lowest: compounds 2, 3 and 1 (each within the scatter of the next).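

In this assay, among these compounds, compound 4 is described only in the words "not toxic", so no step from compound 3 to compound 4 can be read. The compounds shown leave open how nitro in place of methoxy bears on growth inhibition, and no other data shown bear on this.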